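A few compounds are considered here, and "the series" means these few. Any claim that something is new, unique, unknown or untested is made for them only; others in the source may bear on it.

Compound 1 `Oc1nc(-c2cccc(F)c2)nc2ccccc12`, a limit: > 20 ug/mL
Compound 2 `Oc1nc(-c2ccc(F)cc2)nc2ccccc12`, a limit: > 20 ug/mL
Compound 3 `COc1cccc(-c2nc(O)c3ccccc3n2)c1`, a limit: > 20 ug/mL

All three compounds were tested in a functional assay on SK-MEL-2 cells (Homo sapiens) (on this read-out lower numbers stand for an effect already at smaller amounts and higher numbers for an effect only at larger amounts of compound), and none gave a number. Compound 3 thus stands with the others, at the limit of > 20 ug/mL in this assay, at which 3 of the 3 values shown sit. Compound 4 `COc1cccc(-c2nc(O)c3cc(OC)ccc3n2)c1` differs from compound 3 by one change: methoxy in place of hydrogen on an aromatic carbon. Within the data shown here, the only measured step also brings in a methoxy group, a step that the two limits leave unreadable from compound 1 to compound 3, so it offers no size or direction to carry over. In this assay, no step beyond the usual scatter is therefore expected, and another limit is the likeliest result. The expected step is a step that the limit leaves unreadable from compound 3 to compound 4. For compound 4 the estimate is 25 ug/mL, with an expected range from 12 ug/mL to 50 ug/mL.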

Compound 4, concentration for half-maximal effect: > 40 ug/mL
Compound 4 was reported as a limit; the forecaster's own chance of this, stated with the estimate: 80%; middle value at least 1.6-fold (0.20 log units) from the limit.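

Compound 3 and compound 4 are both reported only as limits in this assay, so the step between them cannot be read. The compounds shown leave open at what concentration any of the four would reach half-maximal effect.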